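The source may report more compounds than this note shows. Statements on the series, on what has been measured and on what is new or still open speak of the compounds shown alone.

In an ADME assay on HepG2 cells (Homo sapiens) for cytotoxicity, read by MTT assay, with a stated time of 72 h (on this read-out higher numbers stand for lower toxicity in this test and lower numbers for higher toxicity in this test), compound 2 `CC1(c2ccc(-c3ccc(/C(N)=N\O)cc3)cc2)CC(S(=O)(=O)c2ccc(F)cc2)=C(c2ccc(/C(N)=N\O)cc2)O1` gives 15300 nM, the lowest of the two numbers recorded, while compound 1 `CC1(Cc2ccccc2)CC(S(=O)(=O)c2cccc(F)c2)=C(c2ccc(/C(N)=N\O)cc2)O1` gives 59600 nM, a higher number beyond the scatter. Compound 3 `CC1(c2ccc(-c3ccco3)cc2)CC(S(=O)(=O)c2ccc(F)cc2)=C(c2ccc(/C(N)=N\O)cc2)O1` has not yet been measured in this assay. It differs from compound 2 by a group of 5 heavy atoms (4 carbon, 1 oxygen; one five-membered aromatic ring with 1 hetero atom) in place of a group of 10 heavy atoms (7 carbon, 2 nitrogen, 1 oxygen; one six-membered aromatic ring of carbon only), on an aromatic carbon. Going by the values given here, no measured pair isolates this change; compounds 1 and 2 show only that the analogue lacking the second large group returned the higher number. A moderate rise in this assay is expected, a 2.0-fold higher number from compound 2 to compound 3 (0.29 log units; within the scatter), with wide uncertainty. Compound 3 is estimated at 30000 nM, range 10000 nM to 90000 nM.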

Compound 3, half-maximal cytotoxic concentration: 7010 nM
Compound 3: middle estimate off by 4.3-fold (0.63 log units), on the high side, outside the stated range (below it).
By their numbers in this assay, from the lowest: compound 3; then compound 2; then compound 1.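

At this aromatic carbon, para to a large group, furan-2-yl in place of the larger group with its six-membered aromatic ring gives a 2.2-fold lower number from compound 2 to compound 3 (0.34 log units; beyond the scatter) in this assay. A smaller group with no hydrogen-bond donors therefore does not raise the number at this position, but moves it towards higher toxicity in this test. No measurement available here explains the step. On these data alone, it remains open whether the step comes from the furan-2-yl entering or the larger group leaving. An unsubstituted phenyl or a morpholine on the same carbon would help separate the two.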